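Swapping the amide aryl group on a benzothiophene core

The source may report more compounds than this note shows. Statements on the series, on what has been measured and on what is new or still open speak of the compounds shown alone.

Measured so far:
compound 1 `CCOC(=O)c1sc2ccc(NCc3c[nH]cn3)cc2c1NC(=O)c1ccc(C(F)(F)F)cc1` — 16800 nM
compound 2 `CCOC(=O)c1sc2ccc(NCc3nc[nH]c3C)cc2c1NC(=O)c1cc(OC)c(OC)c(OC)c1` — 2230 nM

Both compounds were tested in a functional assay on HeLa cells (Homo sapiens) for antiproliferative activity, read by MTT assay, with a stated time of 48 h; a lower number here means a stronger inhibitor of growth, a higher number a weaker inhibitor of growth. Of the two numbers available, compound 2 holds the lower one, and compound 1 sits far enough above it that the gap is beyond the usual scatter. Compound 1 and compound 2 differ in two places at once, so it cannot be told from these two numbers alone which of the two changes carries that gap.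

Compound 3 `CCOC(=O)c1sc2ccc(NCc3nc[nH]c3C)cc2c1NC(=O)c1ccc(C(F)(F)F)cc1` keeps the amine side chain of compound 2 and takes only the amide aryl group of compound 1: 4-(trifluoromethyl)phenyl in place of 3,4,5-trimethoxyphenyl on a carbonyl carbon. The step is therefore expected to lie somewhere between no change and the full gap seen from compound 2 to compound 1. The number for compound 3 is expected to be weaker than that of compound 2, with a 3.1-fold higher number from compound 2 to compound 3 (0.50 log units; beyond the scatter) as the estimated step. Compound 3 is estimated at 7000 nM, in a range from 2000 nM to 25000 nM.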

Compound 3, concentration for 50% growth inhibition: 12800 nM
Compound 3: middle estimate off by 1.8-fold (0.26 log units), on the low side; low and high end bracket the measured number.
By their numbers in this assay, from the lowest: compound 2; then compounds 3 and 1 (each within the scatter of the next).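

In this assay, the amide aryl swap taken alone has a clear effect: 4-(trifluoromethyl)phenyl in place of 3,4,5-trimethoxyphenyl on a carbonyl carbon gives a 5.7-fold higher number from compound 2 to compound 3 (0.76 log units; beyond the scatter). The other single change, methyl in place of hydrogen on an aromatic carbon, gives a 1.3-fold lower number from compound 1 to compound 3 (0.12 log units; within the scatter), so with 4-(trifluoromethyl)phenyl on the carbonyl carbon, this methyl has no effect that can be told from the scatter. Together, these two single changes trace the earlier gap, which involved two changes at once, to the amide aryl group rather than to the methyl.

As far as these compounds go, it remains open whether a plain phenyl or a methoxyphenyl group on the same carbonyl carbon would behave like 3,4,5-trimethoxyphenyl, and whether the methyl would stay without effect alongside 3,4,5-trimethoxyphenyl. Nothing measured here gives a reason for the aryl step.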